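The source may report more compounds than this note shows. Statements on the series, on what has been measured and on what is new or still open speak of the compounds shown alone.

Working notes on the series. All three measured compounds were tested in an assay on membranes from HeLa cells for displacement of a labelled ligand from adenosine receptor A3 (Homo sapiens), read by scintillation counting, with a stated time of 180 min, tested at 1 uM; on this read-out lower numbers stand for less inhibition and higher numbers for more inhibition at the one concentration tested (going by the name of the read-out).

Compound 1 `CC1=C(C(=O)OC(C)(C)C)C(c2ccoc2)NC(=O)N1`: 2%
Compound 2 `CC1=C(C(=O)OCc2ccccc2)C(c2ccoc2)NC(=O)N1`: 1%
Compound 3 `CC1=C(C(=O)OC(C)(C)C)C(c2ccoc2)NC(=S)N1`: 19%

The change from compound 1 to compound 2 is benzyl in place of tert-butyl on an oxygen next to a carbonyl group. It gave a number 1 percentage points lower from compound 1 to compound 2 (within the scatter). Compound 3 has a different core from compound 1; the difference between the two cores is not broken down here. Compound 3 shows the highest number of the three, beyond the scatter against both compound 1 and compound 2.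

Compound 4 `CC1=C(C(=O)OCc2ccccc2)C(c2ccoc2)NC(=S)N1` is not yet measured. It differs from compound 3 by benzyl in place of tert-butyl on an oxygen next to a carbonyl group, the same change as from compound 1 to compound 2. In this assay a small step is expected, a number 1 percentage points lower from compound 3 to compound 4 (within the scatter), because a number 1 percentage points lower from compound 1 to compound 2 (within the scatter). Compound 4 is therefore estimated at 18%, expected to fall between 8% and 28%.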

Compound 4, a percentage reported as inhibition, at one concentration (the size of the read-out at that concentration, not a potency): 20%
The estimate for compound 4 lay 2 percentage points below the measured number; the range from low to high includes it.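

In this assay, benzyl in place of tert-butyl on an oxygen next to a carbonyl group gave a number 1 percentage points higher from compound 3 to compound 4 (within the scatter). Set beside the earlier step, this change carries from one core to the other with no difference that can be told from the scatter: the same change on two cores in this assay, a number 1 percentage points lower (within the scatter) from compound 1 to compound 2 and a number 1 percentage points higher (within the scatter) from compound 3 to compound 4, 2 percentage points apart, within the scatter of two such steps This shows only that the change stayed small on these two cores; it gives no direction for the change and does not show that the step would stay small on a further core.

The compounds shown leave open whether a longer chain on that oxygen, or a group carrying an amine or a carboxylic acid, would move the number beyond the scatter. As far as these compounds go, whether either core would respond alike to such groups also remains open.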